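A few compounds are considered here, and "the series" means these few. Any claim that something is new, unique, unknown or untested is made for them only; others in the source may bear on it.

Three compounds share one core. Compound 1 `CC1(C)Cc2c(sc(NC(=O)c3cccnc3O)c2C(N)=O)C(C)(C)O1` carries a 2-hydroxypyridin-3-yl group on the carbonyl carbon of the amide; in an assay on cells for positive allosteric modulation of Cystic fibrosis transmembrane conductance regulator variant F508del (Homo sapiens), with stated times of 10 min and 7 s, in the presence of a further agent that is not named here (on this read-out higher numbers stand for an effect only at larger amounts of compound and lower numbers for an effect already at smaller amounts), compound 1 gives 190 nM. Compound 2 `CC1(C)Cc2c(sc(NC(=O)C(C)(C)O)c2C(N)=O)C(C)(C)O1` carries a 1-hydroxy-1-methylethyl group instead, and in this assay compound 2 gives 16 nM. Compound 3 `CC(C)(C)CC(O)C(=O)Nc1sc2c(c1C(N)=O)CC(C)(C)OC2(C)C` carries a longer chain there, and in this assay compound 3 gives 0.54 nM, the lowest of the three numbers. The steps behind this are a 12-fold lower number from compound 1 to compound 2 (1.07 log units; beyond the scatter), a 350-fold lower number from compound 1 to compound 3 (2.55 log units; beyond the scatter) and a 30-fold lower number from compound 2 to compound 3 (1.47 log units; beyond the scatter).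

Compound 4 `Cc1cc(C(=O)Nc2sc3c(c2C(N)=O)CC(C)(C)OC3(C)C)[nH]n1` changes compound 3 by a group of 6 heavy atoms (4 carbon, 2 nitrogen; one five-membered aromatic ring with 2 hetero atoms) in place of a group of 7 heavy atoms (6 carbon, 1 oxygen; no ring), on a carbonyl carbon. This step returns to an aromatic ring on the carbonyl carbon, as in compound 1, although the ring is a different one. The large move away from an aromatic ring, a 350-fold lower number from compound 1 to compound 3 (2.55 log units; beyond the scatter), is the step that bears most on it, and the reverse direction is therefore expected: a clearly higher number for compound 4, though the different ring leaves the size uncertain. The expected step is a 56-fold higher number from compound 3 to compound 4 (1.74 log units; beyond the scatter), so compound 4 is estimated at 30 nM, within a range from 3 nM to 300 nM.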

Compound 4, half-maximal effective concentration: 13 nM
Beside the measured number, compound 4's estimate is 2.3-fold (0.36 log units) above it; the measured number falls inside the stated range.
By their numbers in this assay, from the lowest: compound 3; then compounds 4 and 2 (each within the scatter of the next); then compound 1.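

Swapping 2-hydroxypyridin-3-yl for 3-methyl-1H-pyrazol-5-yl brings a 15-fold lower number from compound 1 to compound 4 (1.16 log units; beyond the scatter) and so shows that an aromatic ring on this carbonyl carbon need not give a high number; the kind of ring counts, not only its presence. The pyrazole ring and the open-chain 1-hydroxy-1-methylethyl group give nearly the same result, with a 1.2-fold lower number from compound 2 to compound 4 (0.09 log units; within the scatter) in this comparison, while a 24-fold higher number from compound 3 to compound 4 (1.38 log units; beyond the scatter) shows that the ring still falls well short of the longer chain of compound 3. Nothing measured here explains these differences.

From the compounds shown here alone, whether the methyl group on the pyrazole ring contributes remains open, as does the outcome with a plain phenyl ring on this carbonyl carbon. Going by these compounds, it is also open whether an amine could replace the hydroxyl group on the longer chain of compound 3 and keep its low number.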